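The compounds below may be only part of what the source reports. "The series", "measured", "known", "first", "only" and "open" are said of these compounds alone.

Series notes. For the measured compounds named here, compound 1 `CSc1nc(=O)ccn1[C@@H]1O[C@H](COP(=O)(O)OP(=O)(O)O)[C@@H](O)[C@H]1O` carries the longer phosphate chain on the sugar; in an in vitro functional assay on 1321-N1 cells for agonist activity at P2Y purinoceptor 2 (Homo sapiens), read by scintillation proximity assay and inositol phosphate accumulation (a higher number here means that more compound is needed for the effect, a lower number that less compound is needed), compound 1 gives 523 nM, the only number in the set. Compound 2 `Nc1nc(=O)ccn1[C@@H]1O[C@H](COP(=O)(O)O)[C@@H](O)[C@H]1O` is the amino analogue with the shorter chain. For compound 2 this assay reports only a limit, > 100000 nM, not a number; the set thus holds (the limit of > 100000 nM in this assay, at which 1 of the 2 values shown sits). Compound 3 `CSc1nc(=O)ccn1[C@@H]1O[C@H](COP(=O)(O)O)[C@@H](O)[C@H]1O`, not yet measured, differs from compound 1 by a hydrogen atom in place of a group of 4 heavy atoms (3 oxygen, 1 phosphorus; no ring), on an oxygen, and so is the shorter-chain counterpart of compound 1. Going by the values given here, no measured pair in the set isolates this change, so its size is not fixed by any step. The expectation is a large loss in this assay, well beyond the usual scatter, estimated as a 96-fold higher number from compound 1 to compound 3 (1.98 log units; beyond the scatter). Compound 3 is expected near 50000 nM, within the range 5000 nM to 300000 nM, with a fair chance that this assay reports only a limit.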

Compound 3, half-maximal effective concentration: 2900 nM
The estimate for compound 3 lay 17-fold (1.24 log units) above the measured number; the measured number lies below the stated range.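

In this assay, a hydrogen atom in place of the group of 4 heavy atoms (3 oxygen, 1 phosphorus; no ring) on an oxygen is a modest step, a 5.5-fold higher number from compound 1 to compound 3 (0.74 log units; beyond the scatter), so with methylsulfanyl in place the shorter chain still gives a measured number. Methylsulfanyl in place of amino on an aromatic carbon, on the shorter chain, is a large step, an at least 34-fold lower number from compound 2 to compound 3 (1.53 log units; beyond the scatter). Compound 2 is read only as a limit, so this step has a bound and no fixed size: the limit of > 100000 nM in this assay, at which 1 of the 3 values shown sits.

On these data alone, the size of the step from amino to methylsulfanyl on the longer chain remains open. Also open, as far as these compounds go, is how a triphosphate chain on the sugar, or ethylsulfanyl in place of methylsulfanyl, would read in this assay.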